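Trimming the benzyl ether to a plain methoxy

The source may hold more compounds than are shown below. What is called first, only, known or untested is meant among the compounds shown, and "the series" means these compounds.

Compound 2 `O=C1NC(=S)S/C1=C\C=C\c1ccccc1OCc1ccncc1` stands lowest of the two numbers in an assay on isolated protein for inhibition of protein tyrosine phosphatase type IVA 3 (Homo sapiens), tested at 5 ug/mL (a higher number here means more inhibition at the concentration tested (going by the name of the read-out), a lower number less inhibition), where compound 2 gives 39.4%. Among the compounds with values here, its only neighbour is compound 1 `COc1cccc(COc2ccccc2/C=C/C=C2\SC(=S)NC2=O)c1`, which in this assay gives 52.9%; the step of a number 13.5 percentage points lower from compound 1 to compound 2 (beyond the scatter) came with pyridin-4-yl in place of 3-methoxyphenyl on a saturated chain carbon bound to an oxygen on an aromatic ring and lies beyond the scatter. The next compound, compound 3 `COc1ccccc1/C=C/C=C1\SC(=S)NC1=O`, is not yet measured; the change from compound 2 is hydrogen in place of pyridin-4-yl on a saturated chain carbon bound to an oxygen on an aromatic ring. Within the data shown here, only the step from compound 1 to compound 2 bears on this, and it concerns an exchange of one aromatic ring for another rather than its removal, so it is an indirect guide at best. On that basis the expected step is a decrease, a number 11.4 percentage points lower from compound 2 to compound 3 (beyond the scatter), with wide uncertainty. For compound 3 the expected value in this assay is 28%, within 8% to 48%.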

Compound 3, a percentage reported as inhibition, at one concentration (the size of the read-out at that concentration, not a potency): 41.7%
Beside the measured number, compound 3's estimate is 13.7 percentage points below it, and the stated range covers the measured number.
By their numbers in this assay, from the lowest: compounds 2 and 3 (each within the scatter of the next); then compound 1.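

In this assay, hydrogen in place of pyridin-4-yl gives a number 2.3 percentage points higher from compound 2 to compound 3 (within the scatter) and so does not separate (pyridin-4-yl)methoxy from methoxy at this position. Hydrogen in place of 3-methoxyphenyl gives a number 11.2 percentage points lower from compound 1 to compound 3 (beyond the scatter) and so does separate the two groups. Among these three compounds, an aromatic ring on this carbon therefore does not by itself raise the number, since only the 3-methoxyphenyl group stands clear of the plain methoxy, and nothing at hand explains the difference between the two rings.

Open, on these data alone, is whether the 3-methoxyphenyl result depends on its methoxy group or would hold for an unsubstituted phenyl ring on the same carbon. Also open, as far as these compounds go, is how a carboxylic acid or an amine on that ring, or a longer chain in place of the single carbon, would read.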